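Adding a Phenylsulfonyl Group to a Second Core

The source may hold more compounds than are shown below. What is called first, only, known or untested is meant among the compounds shown, and "the series" means these compounds.

Compound 1 `O=C1/C(=C/c2cccnc2)CNC/C1=C\c1ccccc1F` and compound 2 `O=C1/C(=C/c2cccnc2)CN(S(=O)(=O)c2ccccc2)C/C1=C\c1ccccc1F` share one core. In a functional assay on QGY-7703 cells (Homo sapiens) for cytotoxicity, read by MTT assay, with a stated time of 24 h (on this read-out higher numbers stand for weaker inhibition and lower numbers for stronger inhibition), compound 1 gives 8890 nM, and compound 2 gives 4800 nM. Within the data shown here, the only change between them is phenylsulfonyl in place of hydrogen on an amine nitrogen in a ring, and that change gave a 1.9-fold lower number from compound 1 to compound 2 (0.27 log units; within the scatter). Compound 3 `O=C1/C(=C/c2ccncc2)CNC/C1=C\c1ccccc1C(F)(F)F` is built on a different core; the difference between the two cores is not broken down here. In this assay compound 3 gives 4900 nM. Compound 4 `O=C1/C(=C/c2ccncc2)CN(S(=O)(=O)c2ccccc2)C/C1=C\c1ccccc1C(F)(F)F` carries the same change relative to compound 3, namely (phenylsulfonyl in place of hydrogen on an amine nitrogen in a ring), at the same place, on an amine nitrogen in a ring. Because the earlier step was a 1.9-fold lower number from compound 1 to compound 2 (0.27 log units; within the scatter), compound 4 is expected to show a 1.8-fold lower number from compound 3 to compound 4 (0.26 log units; within the scatter). Compound 4 is therefore estimated at 2700 nM, within a range from 1200 nM to 8000 nM.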

Compound 4, half-maximal inhibitory concentration: 6210 nM
Compound 4: the middle estimate sits 2.3-fold (0.36 log units) below what was measured; the measured number falls inside the stated range.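

In this assay, phenylsulfonyl in place of hydrogen on an amine nitrogen in a ring gave a 1.3-fold higher number from compound 3 to compound 4 (0.10 log units; within the scatter). Set beside the earlier step on the other core, this step does not differ from it by more than the usual scatter: the same change on two cores in this assay, a 1.9-fold lower number (0.27 log units; within the scatter) from compound 1 to compound 2 and a 1.3-fold higher number (0.10 log units; within the scatter) from compound 3 to compound 4, 2.3-fold (0.37 log units) apart, within the scatter of two such steps

Neither step lies beyond the scatter, so these four compounds give no sign that the change matters on either core and no sign that the two cores respond differently, but they do not show that it would carry over unchanged to a further core.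

From the compounds shown here alone, it remains open whether a different group on that nitrogen, such as acetyl or benzyl, would give a step beyond the scatter. The same question stands for a phenylsulfonyl ring carrying a methoxy group.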